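Fluoro epimers in the cytotoxicity series

The source may report more compounds than this note shows. Statements on the series, on what has been measured and on what is new or still open speak of the compounds shown alone.

Compound 1 `Nc1ccn([C@@H]2O[C@@](F)(CO)[C@H](F)[C@H]2O)c(=O)n1` gives 23000 nM
Compound 2 `Nc1ccn([C@@H]2O[C@](F)(CO)[C@H](F)[C@H]2O)c(=O)n1` gives 36000 nM
Compound 3 `Nc1ccn([C@@H]2O[C@](F)(CO)[C@@H](F)[C@H]2O)c(=O)n1` is not yet measured

For the measured compounds named here, in an ADME assay on ORL8 cells (Homo sapiens) for cytotoxicity, read by WST assay, with a stated time of 72 h (on this read-out lower numbers stand for higher toxicity in this test and higher numbers for lower toxicity in this test), compound 2 gives 36000 nM and sits within the scatter of compound 1, its only measured neighbour. Compound 3 differs from compound 2 in configuration alone (the two compounds have the same atoms and bonds and differ only in configuration as drawn: 1 of 4 stereo elements differ; a stereocentre at a saturated ring carbon is drawn R in compound 2 and S in compound 3). Going by the values given here, the one measured step (a 1.6-fold higher number from compound 1 to compound 2 (0.19 log units; within the scatter)) was also a change of configuration alone (the fact that compounds 1 and 2 differ only in the configuration as drawn), so no step beyond the scatter is expected for compound 3, though a single step is thin support. The expected step is a 1.1-fold higher number from compound 2 to compound 3 (0.02 log units; within the scatter) and remains only an estimate. Compound 3 is estimated at 38000 nM (expected range 15000 nM to 90000 nM).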

Compound 3, half-maximal cytotoxic concentration: > 50000 nM
Compound 3: a limit, no number (the forecaster's own chance of this, stated with the estimate: 30%); middle value at least 1.3-fold (0.11 log units) from the limit.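

In this assay compound 3 gives > 50000 nM, which is a limit of the assay and not a number. The single change of configuration gives an at least 1.3-fold higher number from compound 2 to compound 3 (0.14 log units; that floor lies within the scatter), so this ring stereocentre has no step beyond the scatter shown for it yet. Two changes of configuration together give an at least 2.1-fold higher number from compound 1 to compound 3 (0.33 log units; beyond the scatter), the first step in the series to clear the scatter, with atoms and bonds unchanged: the fact that compounds 1 and 3 differ only in the configuration as drawn

From the compounds shown here alone, the true value of compound 3 remains open, and with it the size of both steps. Every compound shown carries the same groups, so the reading for an amine or a longer chain in place of a fluoro group remains unknown.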